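One Benzyl Swap, Tried on a Second Core

The source may report more compounds than this note shows. Statements on the series, on what has been measured and on what is new or still open speak of the compounds shown alone.

Compound 1 `Cn1nc(-c2nnc(SCc3cccc(Cl)c3Cl)o2)cc1-c1ccc(C(F)(F)F)cc1` gives 54300 nM in a functional assay on A549 cells (Homo sapiens) for cytotoxicity, read by MTT assay, with a stated time of 24 h; a lower number here means a stronger inhibitor, a higher number a weaker inhibitor.
Compound 2 `Cn1nc(-c2nnc(SCc3ccc(C(F)(F)F)cc3)o2)cc1-c1ccc(C(F)(F)F)cc1` gives 29200 nM in this assay.
Compound 3 `Cn1nc(-c2ccc(C(F)(F)F)cc2)cc1-c1nnc(SCc2cccc(Cl)c2Cl)o1` gives 84200 nM in this assay.

Compound 1 and compound 3 are built from the same atoms joined differently; the difference between the two cores is not broken down here. Compound 2 differs from compound 1 by 4-(trifluoromethyl)phenyl in place of 2,3-dichlorophenyl on a saturated chain carbon bound to a sulfur, and that change gave a 1.9-fold lower number from compound 1 to compound 2 (0.27 log units; within the scatter). Compound 4 `Cn1nc(-c2ccc(C(F)(F)F)cc2)cc1-c1nnc(SCc2ccc(C(F)(F)F)cc2)o1` differs from compound 3 by 4-(trifluoromethyl)phenyl in place of 2,3-dichlorophenyl on a saturated chain carbon bound to a sulfur, the same change at the same place, now on the core of compound 3. Going by the values given here, the step from compound 3 to compound 4 in this assay is expected to be similar in size, estimated at a 1.9-fold lower number from compound 3 to compound 4 (0.28 log units; within the scatter), because a 1.9-fold lower number from compound 1 to compound 2 (0.27 log units; within the scatter) is the only guide available for this change. Compound 4 is therefore expected to give about 44000 nM. Compound 4 is estimated to fall between 22000 nM and 90000 nM.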

Compound 4, half-maximal inhibitory concentration: 39800 nM
The estimate for compound 4 lay 1.1-fold (0.04 log units) above the measured number; the range from low to high includes it.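

In this assay the swap of 2,3-dichlorobenzyl for 4-(trifluoromethyl)benzyl gave a 2.1-fold lower number from compound 3 to compound 4 (0.33 log units; beyond the scatter) as a modest step. Set beside the earlier step, the change carried over from one core to the other at much the same size: the same change on two cores in this assay, a 1.9-fold lower number (0.27 log units; within the scatter) from compound 1 to compound 2 and a 2.1-fold lower number (0.33 log units; beyond the scatter) from compound 3 to compound 4, 1.1-fold (0.06 log units) apart, within the scatter of two such steps. This agreement rests on just two pairs of compounds, so it does not show that the swap would behave the same way on any further core, and it does not explain why the two steps match.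

The compounds shown leave open how an amine, a carboxylic acid or a longer chain in place of either benzyl group would read in this assay. They also leave open whether a third core would follow the same step.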